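Replacing the tetrahydroquinoline of compound 2

This account rests on a few compounds, and the source may have more. Where it says the series, first, only, none or still open, it means among the compounds named here.

Measured in a functional assay on SH-SY5Y cells (Homo sapiens) for inhibition, read by sulforhodamine B assay; a lower number here means a stronger inhibitor, a higher number a weaker inhibitor:
- Compound 1 `COC(=O)CC/C(C)=C/Cc1c(OC)c(C)c2c(c1OCC#CCN1CCN(c3ccccc3F)CC1)C(=O)OC2`: 35800 nM
- Compound 2 `COC(=O)CC/C(C)=C/Cc1c(OC)c(C)c2c(c1OCC#CCN1CCCc3ccccc31)C(=O)OC2`: 9570 nM

Compound 2 has the lower of the two numbers, and its gap to compound 1 lies beyond the scatter. Compound 3 `COC(=O)CC/C(C)=C/Cc1c(OC)c(C)c2c(c1OCC#CCN1CCC(C(=O)OC)CC1)C(=O)OC2` differs from compound 2 by 4-(methoxycarbonyl)piperidin-1-yl in place of 1,2,3,4-tetrahydroquinolin-1-yl on a saturated chain carbon bound to a triple-bonded carbon: 4-(methoxycarbonyl)piperidin-1-yl in place of 1,2,3,4-tetrahydroquinolin-1-yl. Among the measured compounds shown here, no measured pair shows this exact change, so the expectation is rough. It leans on compound 1, which reads higher at 35800 nM. In this assay, the expected change is a moderate move toward weaker inhibition, estimated as a 2.1-fold higher number from compound 2 to compound 3 (0.32 log units; beyond the scatter). For compound 3 the estimated value is 20000 nM, with an expected range of 7000 nM to 60000 nM.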

Compound 3, half-maximal inhibitory concentration: 41200 nM
Compound 3: middle estimate off by 2.1-fold (0.31 log units), on the low side, within the range that was stated.
By their numbers in this assay, from the lowest: compound 2; then compounds 1 and 3 (each within the scatter of the next).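

In this assay, putting 4-(methoxycarbonyl)piperidin-1-yl in place of 1,2,3,4-tetrahydroquinolin-1-yl gives a 4.3-fold higher number from compound 2 to compound 3 (0.63 log units; beyond the scatter) even though the heavy-atom count stays the same. Compound 3 lies within the scatter of compound 1, which leaves compound 2 alone with the lowest number. Nothing available explains this loss of inhibition. The compounds shown leave open whether the loss follows the methoxycarbonyl group or the missing six-membered aromatic ring. A plain piperidin-1-yl group, or a carboxylic acid in place of the ester, would help separate the two.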